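A few compounds are considered here, and "the series" means these few. Any claim that something is new, unique, unknown or untested is made for them only; others in the source may bear on it.

Measured so far in a functional assay on HeLa cells (Homo sapiens) for antiproliferative activity, read by CCK-8 assay, with a stated time of 72 h; on this read-out higher numbers stand for weaker inhibition and lower numbers for stronger inhibition:
- compound 1 `COc1ccccc1C(=O)Nc1cccc(-c2oc3cc(-c4ccc(F)cc4)ccc3c(=O)c2O)c1` gives 14100 nM
- compound 2 `O=C(Nc1cccc(-c2oc3cc(-c4ccc(F)cc4)ccc3c(=O)c2O)c1)c1ccc(Br)cc1` gives 9740 nM
- compound 3 `COc1cccc(C(=O)Nc2cccc(-c3oc4cc(-c5ccc(F)cc5)ccc4c(=O)c3O)c2)c1` gives 5650 nM

Compound 3 holds the lowest number of the three in this assay. Its nearest neighbour is compound 2, and that gap, a 1.7-fold lower number from compound 2 to compound 3 (0.24 log units; within the scatter), stays within the scatter, so no order between compounds 2 and 3 can be read. The gap to compound 1, a 2.5-fold lower number from compound 1 to compound 3 (0.40 log units; beyond the scatter), lies beyond the scatter and is modest.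

The next step leads to compound 4 `CCc1ccc(C(=O)Nc2cccc(-c3oc4cc(-c5ccc(F)cc5)ccc4c(=O)c3O)c2)cc1`. The change is 4-ethylphenyl in place of 3-methoxyphenyl on a carbonyl carbon.

Among the measured compounds shown here, two measured steps bear on this. The step of a 1.7-fold lower number from compound 2 to compound 3 (0.24 log units; within the scatter) also exchanges a 4-substituted phenyl for 3-methoxyphenyl on the same carbonyl carbon and stays within the scatter. The step of a 1.4-fold lower number from compound 1 to compound 2 (0.16 log units; within the scatter) exchanges one aryl group on that carbonyl carbon for another and also stays within the scatter. Only a 2.5-fold lower number from compound 1 to compound 3 (0.40 log units; beyond the scatter) reaches beyond the scatter, and it is modest. Across the three aryl variants on this carbonyl carbon, this assay has so far moved little.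

Compound 4 is therefore expected to show a 1.2-fold higher number from compound 3 to compound 4 (0.09 log units; within the scatter), that is, no step beyond the scatter in either direction. The estimate for compound 4 is 7000 nM, with a range from 2800 nM to 18000 nM.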

Compound 4, half-maximal inhibitory concentration: 21000 nM
Estimate against measurement, compound 4: 3.0-fold (0.48 log units) below, outside the stated range (above it).
By their numbers in this assay, from the lowest: compounds 3, 2, 1 and 4 (each within the scatter of the next, the first and the last beyond it).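

In this assay this position on the carbonyl carbon turns out to be more sensitive than the earlier aryl variants suggested: a 3.7-fold higher number from compound 3 to compound 4 (0.57 log units; beyond the scatter) is the largest step in the set so far, and it comes with an exchange that keeps the heavy-atom count while the ring loses its hydrogen-bond acceptor. Among the compounds shown here, a single exchange of ethyl for bromo on an aromatic carbon also registers, with a 2.2-fold higher number from compound 2 to compound 4 (0.33 log units; beyond the scatter), whereas a 1.5-fold higher number from compound 1 to compound 4 (0.17 log units; within the scatter) gives no order for that pair, so 4-ethylphenyl does not read as worse than every earlier aryl group. No measured data on the compounds accounts for these steps.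

Still open, on these data alone, is whether the step from 3-methoxyphenyl follows the change of group or the change of its ring position, a question that 4-methoxyphenyl and 3-ethylphenyl on the same carbonyl carbon would address. As far as these compounds go, how a methyl, a longer alkyl chain, an amine or a carboxylic acid in place of the ethyl would read in this assay also remains open.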